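Nitro for Methoxy on a Chalcone Core

A few compounds are considered here, and "the series" means these few. Any claim that something is new, unique, unknown or untested is made for them only; others in the source may bear on it.

Of the compounds shown here, three have been measured in an ADME assay on A2780 cells (Homo sapiens) for inhibition, read by trypan blue exclusion, with a stated time of 72 h; a higher number here means a weaker inhibitor of growth, a lower number a stronger inhibitor of growth. Compound 1 `O=C(/C=C/c1ccccc1)c1cccc([N+](=O)[O-])c1` gives 4300 nM. Compound 2 `COc1cccc(C(=O)/C=C/c2ccccc2)c1` gives 8000 nM. Compound 3 `COc1ccccc1C(=O)/C=C/c1ccccc1` gives 7300 nM. Compound 2 and compound 3 are built from the same atoms joined differently; the difference between the two cores is not broken down here.

One structural change is seen once in measured form. Going from compound 2 to compound 1 the change is nitro in place of methoxy on an aromatic carbon, and it made the step of a 1.9-fold lower number from compound 2 to compound 1 (0.27 log units; within the scatter).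

Compound 4 `O=C(/C=C/c1ccccc1)c1ccccc1[N+](=O)[O-]` has not yet been measured. It differs from compound 3 by nitro in place of methoxy on an aromatic carbon. Going by the values given here, this is the same kind of change as the one from compound 2 to compound 1, but not the same: the earlier one sits meta to a large group, the new one sits ortho to a large group.

Among the compounds with values here, for compound 4 a step of about the same size is expected, a 1.8-fold lower number from compound 3 to compound 4 (0.26 log units; within the scatter), because the measured step of a 1.9-fold lower number from compound 2 to compound 1 (0.27 log units; within the scatter) gives the only guide to what this change does, and the starting point of compound 3 at 7300 nM is close to that of compound 2. Compound 4 is therefore estimated to come out at 4000 nM, with a likely range from 2000 nM to 9000 nM.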

Compound 4, concentration for 50% growth inhibition: 5800 nM
Compound 4: middle estimate off by 1.5-fold (0.16 log units), on the low side; low and high end bracket the measured number.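

In this assay, putting nitro in place of methoxy on an aromatic carbon, here ortho to a large group, gives a 1.3-fold lower number from compound 3 to compound 4 (0.10 log units; within the scatter). Set beside the earlier case of the same change, the two steps cannot be told apart: the same change on two cores in this assay, a 1.9-fold lower number (0.27 log units; within the scatter) from compound 2 to compound 1 and a 1.3-fold lower number (0.10 log units; within the scatter) from compound 3 to compound 4, 1.5-fold (0.17 log units) apart, within the scatter of two such steps

So, on these two cores, the change carries across without any measurable sign of depending on the core, and the earlier step was a fair guide to the size of the new one. Going by these compounds alone, this is a modest finding, however: each step is itself within the scatter, so the data do not show that nitro truly gives a stronger inhibitor of growth than methoxy, nor do they show that the change would act alike on every core, since only two pairs have been compared.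

The compounds shown leave open whether a different group at the same place, such as an amine or a carboxylic acid, would give a step large enough to stand clear of the scatter. They also leave open what nitro or methoxy would do elsewhere on the shared core, and a larger set of matched pairs would be needed to settle either question.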